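Cytotoxicity limits across aryl lactam variants of one core

This account rests on a few compounds, and the source may have more. Where it says the series, first, only, none or still open, it means among the compounds named here.

Measured so far:
compound 1, `COc1ccc([C@H]2CC(=O)N(c3ccc(C)c(N)c3)C2)cc1OC1CCCC1`: > 10000 nM
compound 2, `COc1ccc([C@H]2CC(=O)N(c3ccc(C(F)(F)F)cc3)C2)cc1OC1CCCC1`: > 10000 nM
compound 3, `COc1ccc([C@H]2CC(=O)N(c3cccc(S(C)(=O)=O)c3)C2)cc1OC1CCCC1`: > 10000 nM

In a functional assay on HEK293 cells (Homo sapiens) for cytotoxicity (a lower number here means that less compound is tolerated, a higher number that more compound is tolerated), compound 1 gives > 10000 nM, which is a limit of the assay and not a number. Compound 2 likewise gives > 10000 nM, a limit. Compound 3 gives > 10000 nM, again a limit. Compound 3 therefore stands at the same limit as the two other values shown, and no ordering among the three can be read. The steps a step that the two limits leave unreadable from compound 1 to compound 2, a step that the two limits leave unreadable from compound 1 to compound 3 and a step that the two limits leave unreadable from compound 2 to compound 3 are all unreadable for the same reason: the limit of > 10000 nM in this assay, at which 3 of the 3 values shown sit.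

Compound 4, `COc1ccc([C@H]2CC(=O)N(c3cccc(NS(=O)(=O)c4cccc(Br)c4)c3)C2)cc1OC1CCCC1`, differs from compound 3 by ((3-bromophenyl)sulfonyl)amino in place of methylsulfonyl on an aromatic carbon. Within the data shown here, none of the measured steps touches this exact change, and none of them has a readable size, so no measured step gives a direction for this assay here. The three compounds shown agree only in sitting at the limit. The expectation for compound 4 is built on that agreement alone. Compound 4 is estimated at 12000 nM, with a range from 3000 nM to 40000 nM. The step that the limit leaves unreadable from compound 3 to compound 4 expected from this estimate is none beyond the scatter, with a real chance that this assay again reports only a limit.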

Compound 4, half-maximal cytotoxic concentration: > 10000 nM
Compound 4: no number, only a limit; the forecaster's own chance of this, stated with the estimate: 60%; the middle value does not contradict the limit.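

In this assay compound 4 gives > 10000 nM, a limit and not a number. The step from compound 3 to compound 4 cannot be read, and the same holds for the earlier steps: the limit of > 10000 nM in this assay, at which 4 of the 4 values shown sit.

The compounds shown leave open whether any group on the amide-type nitrogen changes the tolerated concentration, and in which direction.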